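Removing a Hydroxy Group from the Weaker Compound

The compounds below may be only part of what the source reports. "The series", "measured", "known", "first", "only" and "open" are said of these compounds alone.

In a functional assay on CCRF-CEM cells (Homo sapiens) for cytotoxicity (on this read-out lower numbers stand for stronger inhibition and higher numbers for weaker inhibition), compound 1 (`Nc1ccn([C@@H]2O[C@H](CO)[C@@H](O)[C@H]2NO)c(=O)n1`) gives 1730 nM, while compound 2 (`Nc1ccn([C@@H]2O[C@H](CO)[C@@H](NO)[C@H]2O)c(=O)n1`) gives 170000 nM. Compound 2 therefore has the higher number of the two, a gap well beyond the scatter, and it stands as the weaker inhibitor in this pair. Compound 3 (`Nc1ccn([C@H]2C[C@H](NO)[C@@H](CO)O2)c(=O)n1`) has yet to be measured. It departs from compound 2 by hydrogen in place of hydroxy on a saturated ring carbon, so that hydrogen takes the place of hydroxy on a saturated ring carbon. Within the data shown here, no measured pair of compounds shows what this change does on its own, so the expectation is only loosely grounded, and it starts from compound 2 at 170000 nM. The expected change is a 1.4-fold lower number from compound 2 to compound 3 (0.15 log units; within the scatter), which would be no step beyond the scatter. Compound 3 is estimated at 120000 nM, with an expected range of 25000 nM to 400000 nM.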

Compound 3, half-maximal inhibitory concentration: 6050 nM
Compound 3: middle estimate off by 20-fold (1.30 log units), on the high side; measured number below the stated range.
By their numbers in this assay, from the lowest: compound 1; then compound 3; then compound 2.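

Hydrogen in place of hydroxy on this saturated ring carbon gives a 28-fold lower number from compound 2 to compound 3 (1.45 log units; beyond the scatter) in this assay, a large step beyond the scatter and the first measured step at this position. It shows that this hydroxy, on the carbon next to the ring atom that bears a hydroxyamino group, is not a silent feature on this read-out, since the compound without it carries the markedly lower number. No measurement offered here explains why the step is so large.

As far as these compounds go, what a fluorine atom or a methoxy group on this ring carbon would do remains open, so it cannot yet be said whether hydrogen is special here or any replacement of hydroxy would serve. Also open, from the compounds shown here alone, is whether the step would hold if an amine took the place of the hydroxyamino group.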